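The compounds below may be only part of what the source reports. "The series", "measured", "known", "first", "only" and "open" are said of these compounds alone.

Working notes on the series. Compound 1 `N#Cc1ccc(Nc2ncc(Cc3c(F)cccc3F)o2)cc1` is the reference point; in an ADME assay on MT2 cells (Homo sapiens) for cytotoxicity, read by MTT assay (on this read-out lower numbers stand for higher toxicity in this test and higher numbers for lower toxicity in this test), compound 1 gives 7400 nM. Compound 2 `Fc1cccc(F)c1Cc1cnc(Nc2ccc(CCOc3ccncc3)cc2)o1` carries 2-((pyridin-4-yl)oxy)ethyl in place of cyano on an aromatic carbon, and in this assay compound 2 gives 11000 nM. Within the data shown here, the one step measured so far, a 1.5-fold higher number from compound 1 to compound 2 (0.17 log units; within the scatter), does not separate the two compounds, so compound 2 stands at a number that compound 1 matches within the scatter.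

Compound 3 `Fc1cccc(F)c1Cc1cnc(Nc2ccc(COCc3ccco3)cc2)o1` has not yet been measured in this assay. Its change from compound 2 is (furan-2-yl)methoxy in place of ((pyridin-4-yl)oxy)methyl on a saturated chain carbon bound to an aromatic carbon. Among the measured compounds shown here, the only step that bears on it is a 1.5-fold higher number from compound 1 to compound 2 (0.17 log units; within the scatter), which exchanged the group on the same aromatic carbon and stayed within the scatter. On that basis compound 3 is expected to show no step beyond the scatter, no change at the digits printed from compound 2 to compound 3 (within the scatter), and compound 3 is estimated at 11000 nM, within a range from 4000 nM to 30000 nM.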

Compound 3, half-maximal cytotoxic concentration: 31000 nM
Compound 3: the middle estimate sits 2.8-fold (0.45 log units) below what was measured; measured number outside the range, above it.
By their numbers in this assay, from the lowest: compounds 1 and 2 (each within the scatter of the next); then compound 3.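

In this assay, among these compounds, the exchange at this position, on a saturated chain carbon bound to an aromatic carbon, moves the number beyond the scatter for the first time: a 2.8-fold higher number from compound 2 to compound 3 (0.45 log units; beyond the scatter), with (furan-2-yl)methoxy entering and ((pyridin-4-yl)oxy)methyl leaving. Against the nitrile of the reference compound, ((furan-2-yl)methoxy)methyl also gives a step beyond the scatter, a 4.2-fold higher number from compound 1 to compound 3 (0.62 log units; beyond the scatter), so on this read-out the group at this aromatic carbon can shift the number toward lower toxicity in this test, whereas the first exchange could not show this. Nothing at hand explains the shift.

This single exchange alters both the aromatic ring and the arrangement of the chain, and the compounds shown do not separate these two changes. Going by these compounds, how a phenyl ring, an amine or a carboxylic acid would read at this place remains open.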